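The compounds below may be only part of what the source reports. "The series", "measured", "known", "first", "only" and "open" are said of these compounds alone.

In a functional assay on A549 cells (Homo sapiens) for antiproliferative activity, read by sulforhodamine B assay, with a stated time of 3 days (on this read-out higher numbers stand for weaker inhibition of growth and lower numbers for stronger inhibition of growth), compound 1 `COc1ccc(N2CCN(C)CC2)cc1Nc1ncc(F)c(Nc2ccc(F)cc2)n1` gives 1130 nM. Compound 2 `O=C(Nc1nccs1)c1cccc(Nc2ncc(F)c(Nc3ccc(F)cc3)n2)c1` stands at a limit of the assay rather than at a number, with > 10000 nM. Compound 3 `COc1ccc(NC(=O)c2cccc(Nc3ncc(F)c(Nc4ccc(F)cc4)n3)c2)cc1` carries 4-methoxyphenyl in place of the 1,3-thiazol-2-yl of compound 2 on an amide-type nitrogen (4-methoxyphenyl in place of 1,3-thiazol-2-yl on an amide-type nitrogen). Within the data shown here, no measured pair shows what this change does in this assay, so only a modest shift toward stronger inhibition of growth is expected. The estimated change is an at least 2.0-fold lower number from compound 2 to compound 3 (0.30 log units; that floor lies within the scatter). Compound 3 is expected to give 5000 nM, with an estimated range from 1500 nM to 10000 nM.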

Compound 3, concentration for 50% growth inhibition: 11000 nM
Estimate against measurement, compound 3: 2.2-fold (0.34 log units) below; the whole stated range lies below it.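

The step from compound 2 to compound 3 in this assay cannot be read, because compound 2 stands at a limit of the assay: the limit of > 10000 nM in this assay, at which 1 of the 3 values shown sits. The compounds shown leave open how 4-methoxyphenyl and 1,3-thiazol-2-yl compare on the amide-type nitrogen.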